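A Methyl Step Repeated, From Ester to Amide

The source may report more compounds than this note shows. Statements on the series, on what has been measured and on what is new or still open speak of the compounds shown alone.

Compound 1 `C=CCOC(=O)/C=C(C)/C=C/CC(C)CCCC(C)(C)OC` and compound 2 `C=CC(C)OC(=O)/C=C(C)/C=C/CC(C)CCCC(C)(C)OC` differ by methyl in place of hydrogen on a saturated chain carbon bound to a double-bonded chain carbon and an oxygen next to a carbonyl group. In a physicochemical assay for lipophilicity (on this read-out higher numbers stand for higher lipophilicity and lower numbers for lower lipophilicity), compound 1 gives 5.53, while compound 2 gives 5.94, the step being a number 0.41 log units higher from compound 1 to compound 2 (beyond the scatter). Compound 3 `CCNC(=O)/C=C(C)/C=C/CC(C)CCCC(C)(C)OC` differs from compound 1 in its core by ethylamino in place of allyloxy on a carbonyl carbon; in this assay compound 3 gives 4.04, a step of a number 1.49 log units lower from compound 1 to compound 3 (beyond the scatter). Compound 4 `COC(C)(C)CCCC(C)C/C=C/C(C)=C/C(=O)NC(C)C` carries methyl in place of hydrogen on a saturated chain carbon bound to an amide-type nitrogen and a saturated chain carbon. This is the same kind of change as in the pair before, though the place differs: there the saturated chain carbon is bound to a double-bonded chain carbon and an oxygen next to a carbonyl group, here to an amide-type nitrogen and a saturated chain carbon. The expected step of a number 0.40 log units higher from compound 3 to compound 4 (beyond the scatter) is taken to resemble a number 0.41 log units higher from compound 1 to compound 2 (beyond the scatter), resting on that single earlier step. Compound 4 is therefore estimated at 4.44 in this assay, expected between 4.1 and 4.8.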

Compound 4, partition coefficient: 4.45
Estimate against measurement, compound 4: 0.01 log units below; the range from low to high includes it.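

In this assay the methyl step on the second core reads a number 0.41 log units higher from compound 3 to compound 4 (beyond the scatter), matching a number 0.41 log units higher from compound 1 to compound 2 (beyond the scatter) in size, so this change carried over between these two cores. Replacing the oxygen-linked groups with isopropylamino on a carbonyl carbon remains a large change, at a number 1.08 log units lower from compound 1 to compound 4 (beyond the scatter) and a number 1.49 log units lower from compound 2 to compound 4 (beyond the scatter). For the compounds shown here, with only one pair on each core, this sets no rule for other cores or places, and no measured evidence explains the agreement.

The compounds shown leave open how tert-butylamino or cyclopropylamino on a carbonyl carbon would read. They also leave open what a carboxylic acid would give.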